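Working notes: the step from compound 2 to compound 3

A few compounds are considered here, and "the series" means these few. Any claim that something is new, unique, unknown or untested is made for them only; others in the source may bear on it.

Measured in a functional assay on MCF7 cells (Homo sapiens) for inhibition, read by MTT assay, with a stated time of 24 h; on this read-out higher numbers stand for weaker inhibition of growth and lower numbers for stronger inhibition of growth:
- compound 1 `COc1ccc2c(c1)c(-c1nc3ccccc3n1C(=O)c1ccccc1Br)cn2C`: 55800 nM
- compound 2 `COc1ccc(C(=O)n2c(-c3cn(C)c4ccc(Br)cc34)nc3ccccc32)cc1`: 19200 nM

Compound 2, at 19200 nM, holds the lower of the two numbers in this assay, and the gap up to compound 1 lies beyond the scatter. Among the compounds with values here, both numbers are high, and the series so far offers only these two points.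

The next compound is compound 3 `Cn1cc(-c2nc3ccccc3n2C(=O)c2ccccc2Br)c2cc(Br)ccc21`. Its difference from compound 2 is 2-bromophenyl in place of 4-methoxyphenyl on a carbonyl carbon.

Within the data shown here, no measured pair differs in one place only, so this change has no direct precedent and the expectation rests on thin ground. Among the measured compounds shown here, the only guide is compound 1, which also carries 2-bromophenyl on a carbonyl carbon and gives 55800 nM, the higher number. The expected step is a 1.8-fold higher number from compound 2 to compound 3 (0.26 log units; within the scatter), towards weaker inhibition of growth and probably within the scatter.

For compound 3 the expected value is 35000 nM, with an estimated range from 14000 nM to 80000 nM.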

Compound 3, concentration for 50% growth inhibition: 73600 nM
The estimate for compound 3 lay 2.1-fold (0.32 log units) below the measured number; low and high end bracket the measured number.
By their numbers in this assay, from the lowest: compound 2; then compounds 1 and 3 (each within the scatter of the next).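

In this assay, within the data shown here, 2-bromophenyl in place of 4-methoxyphenyl on a carbonyl carbon gives a 3.8-fold higher number from compound 2 to compound 3 (0.58 log units; beyond the scatter) as the first reading of this position with the rest of the molecule held constant, and it shows that this change moves towards weaker inhibition of growth. Among these compounds, with 2-bromophenyl held on the carbonyl carbon, bromo in place of methoxy on an aromatic carbon gives a 1.3-fold higher number from compound 1 to compound 3 (0.12 log units; within the scatter) and so leaves no readable difference in this pair, which makes the carbonyl substituent the only place so far with a step beyond the scatter. Nothing available here accounts for the size of the step at the carbonyl carbon.

The single step changes both the substituent and where it sits on the phenyl ring, so the compounds shown leave open whether 4-bromophenyl or 2-methoxyphenyl on the carbonyl carbon would follow compound 2 or compound 3. They also leave open how an unsubstituted phenyl or a 4-aminophenyl at this place would read, and whether the step holds with methoxy in place of bromo on the core.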